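This account rests on a few compounds, and the source may have more. Where it says the series, first, only, none or still open, it means among the compounds named here.

Results so far in a functional assay on the whole organism (heart) with Rattus norvegicus as the target; on this read-out higher numbers stand for an effect only at larger amounts of compound and lower numbers for an effect already at smaller amounts:
- compound 1 `CC(=O)/C(=C\c1ccccc1)Oc1ccc(OCC(O)NC(C)(C)C)cc1` gives 3.5 mg/kg
- compound 2 `CC(=O)/C(=C\c1ccccc1)Oc1ccccc1OCC(O)CNC(C)(C)C` gives 1.9 mg/kg

Compound 2 at 1.9 mg/kg lies within the scatter of compound 1, so the two values do not separate. Compound 3 `CC(=O)/C(=C\c1ccccc1)Oc1ccccc1OCC(O)CN1CCN(C)CC1` carries 4-methylpiperazin-1-yl in place of (tert-butyl)amino on a saturated chain carbon, two bonds along the chain from an oxygen on a saturated carbon and awaits measurement. Within the data shown here, no pair of measured compounds shows this exchange, so the expectation rests on the structural change alone: a modest move to a higher number in this assay is expected. The expected step is a 3.2-fold higher number from compound 2 to compound 3 (0.50 log units; beyond the scatter) and it may stay within the scatter. Compound 3 is estimated at 6 mg/kg (range 2 mg/kg to 25 mg/kg).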

Compound 3, dose for half-maximal effect: 7.5 mg/kg
For compound 3 the middle estimate is 1.3-fold (0.10 log units) below the measured one, and the stated range covers the measured number.
By their numbers in this assay, from the lowest: compounds 2 and 1 (each within the scatter of the next); then compound 3.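

In this assay, 4-methylpiperazin-1-yl in place of (tert-butyl)amino on a saturated chain carbon, two bonds along the chain from an oxygen on a saturated carbon, gives a 3.9-fold higher number from compound 2 to compound 3 (0.60 log units; beyond the scatter). Among these compounds, the earlier compounds did not separate, so this is the first change here that moves the number beyond the scatter, and the amine at this place matters for the read-out. Nothing available explains this step. The compounds shown leave open whether the ring or its methyl group accounts for the step, and how a simpler isopropylamino group or a morpholin-4-yl ring would read at this place.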